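Replacing the chloro of compound 2 with methyl

The source may hold more compounds than are shown below. What is called first, only, known or untested is meant among the compounds shown, and "the series" means these compounds.

Measured in a functional assay on SK-BR-3 cells (Homo sapiens) for antiproliferative activity, read by CCK-8 assay and cell counting, with a stated time of 72 h; a higher number here means a weaker inhibitor, a lower number a stronger inhibitor:
- compound 1 `O=C(Nc1ccccc1NC(=O)c1ccc(CO[N+](=O)[O-])cc1)c1ccc(CO[N+](=O)[O-])cc1`: > 100000 nM
- compound 2 `O=C(Nc1ccccc1)c1ccc(CCl)cc1`: 700 nM
- compound 3 `O=C(Nc1ccccc1)c1cccc(CO[N+](=O)[O-])c1`: 8200 nM

The entry for compound 1 is a limit, > 100000 nM. Of the two actual numbers, compound 2 stands lowest at 700 nM, and the gap to compound 3 at 8200 nM lies beyond the scatter.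

Compound 4 `CCc1ccc(C(=O)Nc2ccccc2)cc1` departs from compound 2 in one place: methyl in place of chloro on a saturated chain carbon bound to an aromatic carbon. Chloromethyl thus becomes ethyl. Among the measured compounds shown here, no measured pair isolates this change in this assay. Compound 3, which has no chloromethyl, gives 8200 nM, so a move to a higher number, beyond the scatter, is expected. The expected step is an 8.6-fold higher number from compound 2 to compound 4 (0.93 log units; beyond the scatter). For compound 4 the estimate is 6000 nM, with an expected range of 1500 nM to 30000 nM.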

Compound 4, half-maximal inhibitory concentration: > 100000 nM
Compound 4: only a limit was reported; the forecaster's own chance of this, stated with the estimate: 10%; middle value at least 16-fold (1.22 log units) from the limit.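

Methyl in place of chloro on a saturated chain carbon bound to an aromatic carbon is the first change isolated here in a single pair, and it brings an at least 140-fold higher number from compound 2 to compound 4 (2.15 log units; beyond the scatter) and shows that this place does not tolerate the swap. In this assay compound 4 gives > 100000 nM as a limit, not a number. The step therefore has no upper bound: the limit of > 100000 nM in this assay, at which 2 of the 4 values shown sit.

The compounds shown leave open whether bromo, hydroxyl or an amine at this place would hold the activity of compound 2. They also leave open whether a longer chain ending in chloro would do so.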